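Cytotoxicity notes: from compound 1 toward compound 4

A few compounds are considered here, and "the series" means these few. Any claim that something is new, unique, unknown or untested is made for them only; others in the source may bear on it.

Compound 1 `O=C(/C=C/c1ccc([N+](=O)[O-])o1)c1ccc(N2CCNCC2)cc1` stands at the edge of what an ADME assay on THP-1 cells (Homo sapiens) for cytotoxicity, read by resazurin assay, with a stated time of 72 h (on this read-out higher numbers stand for lower toxicity in this test and lower numbers for higher toxicity in this test), reports: in this assay compound 1 gives > 50000 nM, which is a limit and not a number. Compound 3 `CC(C)(C)c1ccc(C(=O)/C=C/c2ccco2)cc1` likewise returns only a limit in this assay, > 50000 nM. Among the measured compounds shown here, compound 2 `Cc1ccccc1C(=O)/C=C/c1ccc([N+](=O)[O-])o1` is the single compound with a measured number in this assay, 27900 nM. For the measured compounds named here, two of the three values thus sit at the same limit (the limit of > 50000 nM in this assay, at which 2 of the 3 values shown sit), so no step between measured compounds can be sized. Compound 4 `O=C(/C=C/c1ccc([N+](=O)[O-])o1)c1ccc(I)cc1` carries iodo in place of piperazin-1-yl on an aromatic carbon. In this assay a modest step toward higher toxicity is expected, an at least 1.6-fold lower number from compound 1 to compound 4 (0.22 log units; that floor lies within the scatter). Compound 4 is expected to give about 30000 nM in this assay, within 10000 nM to 60000 nM.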

Compound 4, half-maximal cytotoxic concentration: 49500 nM
Estimate against measurement, compound 4: 1.7-fold (0.22 log units) below; the range from low to high includes it.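

On an aromatic carbon para to a large group, iodo in place of piperazin-1-yl yields a measurable value: in this assay compound 4 gives 49500 nM. In this assay compound 1 gives > 50000 nM, which is a limit and not a number. The step is a number no higher from compound 1 to compound 4 (the limit leaves the size open), and the reading is constrained by this limit: the limit of > 50000 nM in this assay, at which 2 of the 4 values shown sit.

As far as these compounds go, what a carboxylic acid or a fluoro group at this aromatic carbon would give on the core of compound 1 remains open. Also open, from the compounds shown here alone, is whether any replacement of piperazin-1-yl here moves the value beyond the usual scatter.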